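A few compounds are considered here, and "the series" means these few. Any claim that something is new, unique, unknown or untested is made for them only; others in the source may bear on it.

Working notes on the series. Three compounds carry a number in a functional assay on SK-BR-3 cells (Homo sapiens) for antiproliferative activity, read by MTT assay, with a stated time of 72 h; on this read-out higher numbers stand for weaker inhibition and lower numbers for stronger inhibition. Compound 1 `CCN1CCN(c2cc(C)c3cc(NC(=O)c4cccnc4)ccc3n2)CC1` gives 10600 nM; compound 3 `CCN1CCN(c2cc(C)c3cc(NC(=O)c4ccccc4OC)ccc3n2)CC1` gives 15700 nM; compound 2 `Cc1cc(N2CCCCC2)nc2ccc(NC(=O)c3ccc(Cl)c(Cl)c3)cc12` gives 42500 nM. Among the compounds with values here, the one step between compounds that differ in a single place is a 1.5-fold higher number from compound 1 to compound 3 (0.17 log units; within the scatter), so the exchange at the carbonyl carbon leaves the read-out essentially unchanged. Compound 2 stands at the highest number of the three, a gap to compound 3 and a larger one to compound 1, both beyond the scatter, though compound 2 also differs from those two at more than one place, so no single step explains where it stands.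

Compound 4 `Cc1cc(NCCN2CCCCC2)nc2ccc(NC(=O)c3ccc(Cl)c(Cl)c3)cc12` follows from compound 2 by one change: (2-(piperidin-1-yl)ethyl)amino in place of piperidin-1-yl on an aromatic carbon. Within the data shown here, no measured step in this assay touches the group on that aromatic carbon; the only step known concerns the amide aryl group and lies within the scatter. There is therefore no basis for expecting a step beyond the scatter in either direction, and the estimate for compound 4 is set close to compound 2 with a wide range. Compound 4 is expected to give 30000 nM, between 8000 nM and 100000 nM, which amounts to an expected 1.4-fold lower number from compound 2 to compound 4 (0.15 log units; within the scatter).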

Compound 4, half-maximal inhibitory concentration: 1800 nM
Compound 4: the middle estimate sits 17-fold (1.22 log units) above what was measured; the whole stated range lies above it.
By their numbers in this assay, from the lowest: compound 4; then compounds 1 and 3 (each within the scatter of the next); then compound 2.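

In this assay, within the data shown here, the group on the aromatic carbon next to the ring nitrogen proves to be a far more sensitive place than the carbonyl carbon: (2-(piperidin-1-yl)ethyl)amino in place of piperidin-1-yl gives a 24-fold lower number from compound 2 to compound 4 (1.37 log units; beyond the scatter), whereas the only earlier step, a 1.5-fold higher number from compound 1 to compound 3 (0.17 log units; within the scatter), stayed within the scatter. The six-membered non-aromatic ring is present on both sides of this change, so what differs is how it is attached: the entering group places an ethyl chain and an amino nitrogen, with its hydrogen-bond donor, between that ring and the aromatic carbon. Nothing at hand accounts for the size of this step.

The compounds shown do not separate the contribution of the amino nitrogen from those of the chain and the terminal piperidine ring, so a simple 2-(dimethylamino)ethylamino group, a three-carbon propyl chain or a terminal morpholine would each test a different part of the entering group. Going by these compounds, it also remains open whether the same exchange gives a comparable step with the amide groups of compound 1 and compound 3.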